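Removing one fluoro from compound 2

This account rests on a few compounds, and the source may have more. Where it says the series, first, only, none or still open, it means among the compounds named here.

Going by the values given here, in a functional assay on HT-29 cells (Homo sapiens) for antiproliferative activity, read by MTT assay, with a stated time of 72 h (a higher number here means a weaker inhibitor, a lower number a stronger inhibitor), compound 1 `O=c1c(-c2ccc(F)cc2)c[nH]c2ccnc(Nc3ccc(Oc4ccnc5cc(OCCO)ccc45)c(F)c3)c12` gives 5500 nM and compound 2 `CC(C)(O)COc1ccc2c(Oc3ccc(Nc4nccc5[nH]cc(-c6ccc(F)cc6)c(=O)c45)cc3F)ccnc2c1` gives 3400 nM, so compound 2 stands level with the only other measured compound. Compound 3 `CC(C)(O)COc1ccc2c(Oc3ccc(Nc4nccc5[nH]cc(-c6ccccc6)c(=O)c45)cc3F)ccnc2c1` carries hydrogen in place of fluoro on an aromatic carbon, turning 4-fluorophenyl to phenyl (hydrogen in place of fluoro on an aromatic carbon). Among the compounds with values here, the one measured step, a 1.6-fold lower number from compound 1 to compound 2 (0.21 log units; within the scatter), lies elsewhere in the molecule, so no measured step tests this change directly. Nothing beyond the scatter is expected in this assay, with an estimated 1.1-fold higher number from compound 2 to compound 3 (0.02 log units; within the scatter). Compound 3 is expected at 3600 nM, within an estimated range of 1500 nM to 8500 nM.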

Compound 3, half-maximal inhibitory concentration: 4200 nM
Compound 3: the middle estimate sits 1.2-fold (0.07 log units) below what was measured; the range from low to high includes it.
By their numbers in this assay, from the lowest: compounds 2, 3 and 1 (each within the scatter of the next).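

In this assay, putting hydrogen in place of fluoro on the 4-fluorophenyl group gives a 1.2-fold higher number from compound 2 to compound 3 (0.09 log units; within the scatter) and so shows that this fluoro can go without a shift that stands out from the scatter. Going by these compounds alone, this is the first measured step at this ring, since the earlier step lay elsewhere in the molecule. Nothing available offers an explanation for this result. Still open, as far as these compounds go, is whether a different group at this place, such as an amine, a methoxy group or a carboxylic acid, would move the number beyond the scatter.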